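The compounds below may be only part of what the source reports. "The series", "measured", "known", "first", "only" and "open" are said of these compounds alone.

Among the compounds with values here, in a functional assay on HepG2 cells (Homo sapiens) for antiproliferative activity, read by MTT assay, with a stated time of 72 h (on this read-out higher numbers stand for weaker inhibition and lower numbers for stronger inhibition), three compounds sharing one core have numbers so far. Compound 1 `O=C(N/N=C/c1cccc([N+](=O)[O-])c1)Nc1ccc(Oc2ccnc3[nH]ccc23)c(F)c1` gives 5180 nM in this test, compound 2 `O=C(N/N=C/c1ccc([N+](=O)[O-])cc1)Nc1ccc(Oc2ccnc3[nH]ccc23)c(F)c1` gives 3030 nM in it, and compound 3 `O=C(N/N=C/c1ccc(F)cc1Cl)Nc1ccc(Oc2ccnc3[nH]ccc23)c(F)c1` gives 1110 nM as the lowest number of the three. Compound 3 therefore stands as the strongest inhibitor of the set, since a 4.7-fold lower number from compound 1 to compound 3 (0.67 log units; beyond the scatter) and a 2.7-fold lower number from compound 2 to compound 3 (0.44 log units; beyond the scatter) both separate it from the others, if only modestly. By contrast, a 1.7-fold lower number from compound 1 to compound 2 (0.23 log units; within the scatter) shows no real difference between the two nitrophenyl compounds.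

Compound 4 `O=C(N/N=C/c1ccc(O)cc1)Nc1ccc(Oc2ccnc3[nH]ccc23)c(F)c1` has 4-hydroxyphenyl in place of 2-chloro-4-fluorophenyl on a carbon with a double bond to nitrogen, a difference counted as 4-hydroxyphenyl in place of 2-chloro-4-fluorophenyl on a carbon with a double bond to nitrogen here. Within the data shown here, all three measured steps change the group at this same place, but no measured compound carries 4-hydroxyphenyl, so they bear on the change only indirectly. Both groups tried instead of 2-chloro-4-fluorophenyl gave higher numbers, as a 2.7-fold lower number from compound 2 to compound 3 (0.44 log units; beyond the scatter) and a 4.7-fold lower number from compound 1 to compound 3 (0.67 log units; beyond the scatter) show when read in reverse. A modest loss is therefore expected, of similar size to those steps, and the estimate is a 2.5-fold higher number from compound 3 to compound 4 (0.40 log units; beyond the scatter) in the direction of weaker inhibition. Compound 4 is estimated at 2800 nM in this assay, with an expected range from 900 nM to 8000 nM as its limits.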

Compound 4, half-maximal inhibitory concentration: 1950 nM
Beside the measured number, compound 4's estimate is 1.4-fold (0.16 log units) above it; the measured number falls inside the stated range.
By their numbers in this assay, from the lowest: compounds 3, 4, 2 and 1 (each within the scatter of the next, the first and the last beyond it).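

In this assay, the place on the carbon with a double bond to nitrogen now shows that a 4-hydroxyphenyl group, with its hydrogen-bond donor and acceptor, can stand in for 2-chloro-4-fluorophenyl, which has neither: a 1.8-fold higher number from compound 3 to compound 4 (0.24 log units; within the scatter) stays inside the scatter. The change of nitro to hydroxy on an aromatic carbon also gives no clear separation, with a 1.6-fold lower number from compound 2 to compound 4 (0.19 log units; within the scatter) as its step, while a 2.7-fold lower number from compound 1 to compound 4 (0.42 log units; beyond the scatter) is a modest step beyond the scatter, so the 3-nitrophenyl group of compound 1 is now set apart from two other groups at this place rather than from one. What lies behind these small differences cannot be said, since no measurement shown here addresses it.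

The compounds shown leave open whether a methoxy group or an amine in place of the hydroxy on the aromatic carbon would stay within this same narrow range. They also leave open whether a carboxylic acid on that ring, or a longer chain between the ring and the carbon with a double bond to nitrogen, would move the number further than any group seen so far.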